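The compounds below may be only part of what the source reports. "The series", "measured", "known", "first", "only" and "open" are said of these compounds alone.

Compound 1 `O=C(NC(=S)N1CCc2c(OCCCCCOc3ccc(Cl)cc3)cccc21)c1ccc([N+](=O)[O-])cc1` gives 13600 nM in an ADME assay on Huh-7 cells (Homo sapiens) for cytotoxicity; a lower number here means that less compound is tolerated, a higher number that more compound is tolerated. Compound 2 `N#Cc1ccc(C(=O)NC(=S)N2CCc3c(OCCCCCOc4ccc(Cl)cc4)cccc32)cc1` reaches only the limit of this assay, > 50000 nM. Compound 3 `CCCC(=O)NC(=S)N1CCc2c(OCCCCCOc3ccc(Cl)cc3)cccc21` likewise sits at the limit, > 50000 nM, a boundary rather than a number, shared with compound 2 (the limit of > 50000 nM in this assay, at which 2 of the 3 values shown sit).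

Compound 4 `O=C(NC(=S)N1CCc2c(OCCCCCOc3ccc(Cl)cc3)cccc21)c1cccs1` is made from compound 3 by thiophen-2-yl in place of propyl on a carbonyl carbon. Going by the values given here, the closest measured step is an at least 3.6-fold higher number from compound 1 to compound 3 (0.56 log units; beyond the scatter), where the aryl group of compound 1 was the only one giving a readable number; an at least 3.6-fold higher number from compound 1 to compound 2 (0.56 log units; beyond the scatter) shows that another aryl group reached the limit, and a step that the two limits leave unreadable from compound 2 to compound 3 cannot be sized. Returning to an aromatic ring therefore leaves compound 4 expected anywhere from a number near compound 1 up to the limit; the estimated step of an at least 1.6-fold lower number from compound 3 to compound 4 (0.22 log units; that floor lies within the scatter) is expected to be downward but uncertain, with compound 4 estimated at 30000 nM (range 10000 nM to 100000 nM).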

Compound 4, half-maximal cytotoxic concentration: 10700 nM
Estimate against measurement, compound 4: 2.8-fold (0.45 log units) above; the measured number falls inside the stated range.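

In this assay, the result shows that a low number at this carbonyl carbon is not peculiar to 4-nitrophenyl: thiophen-2-yl in place of propyl gives an at least 4.6-fold lower number from compound 3 to compound 4 (0.66 log units; beyond the scatter). Aromatic rings here still do not behave alike, since thiophen-2-yl in place of 4-cyanophenyl gives an at least 4.6-fold lower number from compound 2 to compound 4 (0.66 log units; beyond the scatter), and compound 2 goes against any rule that an aromatic ring lowers the number. The two rings with readable values cannot be told apart, with a 1.3-fold lower number from compound 1 to compound 4 (0.10 log units; within the scatter).

Going by these compounds, how far compound 2 and compound 3 differ cannot be read: the limit of > 50000 nM in this assay, at which 2 of the 4 values shown sit. Whether a longer chain than propyl, or a cyclohexyl group, on this carbonyl carbon stays at the limit remains open.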